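The source may hold more compounds than are shown below. What is called first, only, known or untested is meant among the compounds shown, and "the series" means these compounds.

Measured compounds in a functional assay on HEK293 cells for antagonist activity at proteinase-activated receptor 4 (Homo sapiens), read by FLIPR and calcium flux, with a stated time of 30 min; on this read-out higher numbers stand for weaker inhibition and lower numbers for stronger inhibition:
compound 1 `COc1cc(OCc2ccccc2OC)c2cc(-c3cn4nc(OC)sc4n3)oc2c1`: 19 nM
compound 2 `c1ccc(Sc2nn3cc(-c4cc5ccccc5o4)nc3s2)cc1`: 1900 nM
compound 3 `COc1cc(OCc2cccc(COc3ccccc3)c2)c2cc(-c3cn4nc(OC)sc4n3)oc2c1`: 3.2 nM

Among these three, compound 1 stands second highest. The nearest number belongs to compound 3, whose value of 3.2 nM is lower by a margin beyond the usual scatter; the furthest belongs to compound 2, whose 1900 nM lies far higher.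

The unmeasured compound 4 `COc1cc(OCc2ccccc2OCc2ccccc2)c2cc(-c3cn4nc(OC)sc4n3)oc2c1` differs from compound 1 in one place: phenyl in place of hydrogen on a saturated chain carbon bound to an oxygen on an aromatic ring. The shared core and the rest of the molecule are unchanged.

Among the measured compounds shown here, no measured pair shows this exact change. What the numbers do show is that compound 3, which carries a larger group on the same part of the molecule, gives a lower value than compound 1, so an added phenyl there is not expected to raise the number. For compound 4 the step of a 2.1-fold lower number from compound 1 to compound 4 (0.32 log units; beyond the scatter) is expected to be modest and downward, though possibly within the scatter. Compound 4 is therefore estimated at 9 nM, with a range from 2.5 nM to 35 nM.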

Compound 4, half-maximal inhibitory concentration: 3.2 nM
Beside the measured number, compound 4's estimate is 2.8-fold (0.45 log units) above it; the range from low to high includes it.
By their numbers in this assay, from the lowest: compounds 3 and 4 (each within the scatter of the next); then compound 1; then compound 2.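

In this assay the change from methoxy to benzyloxy gives a 5.9-fold lower number from compound 1 to compound 4 (0.77 log units; beyond the scatter) and is the first step among these compounds that can be read at a single place. It shows that a phenyl on a saturated chain carbon bound to an oxygen on an aromatic ring is accompanied by a lower number, with the rest of the molecule unchanged. Nothing given here offers an explanation for this step.

The compounds shown leave open whether a cyclohexyl or a pyridyl group in place of this phenyl would give a similar number. They also leave open how a longer chain carrying the phenyl, or an amine or a carboxylic acid on the phenyl, would read at this place.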